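Chloro for trifluoromethyl at a second ring position

The compounds below may be only part of what the source reports. "The series", "measured", "known", "first", "only" and "open" are said of these compounds alone.

The series is assessed in a functional assay on SK-BR-3 cells (Homo sapiens) for antiproliferative activity, with a stated time of 48 h; on this read-out lower numbers stand for an effect already at smaller amounts and higher numbers for an effect only at larger amounts of compound. Compound 1 `O=C(CCCCCCC(=O)Nc1cccc(C(F)(F)F)c1)NO` gives 26000 nM, the highest of the three measured numbers; compound 2 `O=C(CCCCCCC(=O)Nc1ccc(C(F)(F)F)cc1)NO` gives 2200 nM and compound 3 `O=C(CCCCCCC(=O)Nc1ccc(Cl)cc1)NO` gives 2300 nM. Compound 1 and compound 2 are built from the same atoms joined differently; the difference between the two cores is not broken down here, and the values alone show compound 1 standing well beyond the scatter from compound 2 in this assay.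

One change is measured directly: chloro in place of trifluoromethyl on an aromatic carbon. Its step, a 1.0-fold higher number from compound 2 to compound 3 (0.02 log units; within the scatter), lies within the scatter. Compound 4 `O=C(CCCCCCC(=O)Nc1cccc(Cl)c1)NO` carries the same kind of change made on compound 1: chloro in place of trifluoromethyl on an aromatic carbon. The two places are not the same word for word: in compound 3 the chloro sits para to a large group, in compound 4 meta to a large group, so this is the same kind of change rather than the same change, and only the para instance has been measured.

For compound 4 the expected step is no change at the digits printed from compound 1 to compound 4 (within the scatter), because a 1.0-fold higher number from compound 2 to compound 3 (0.02 log units; within the scatter) lay within the scatter. In this assay compound 4 is therefore estimated at 26000 nM, with a likely range from 11000 nM to 60000 nM. Within the data shown here, the range is kept wide since the single measured instance sits at a different place and the core of compound 1 is already the weakest measured.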

Compound 4, half-maximal effective concentration: 2000 nM
Compound 4: the middle estimate sits 13-fold (1.11 log units) above what was measured; the whole stated range lies above it.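

Chloro in place of trifluoromethyl gives a 13-fold lower number from compound 1 to compound 4 (1.11 log units; beyond the scatter) in this assay on an aromatic carbon meta to a large group, and this is a large step rather than a small adjustment. The same kind of change therefore does not carry over as one fixed step between the two cores in this series: the same change on two cores in this assay, a 1.0-fold higher number (0.02 log units; within the scatter) from compound 2 to compound 3 and a 13-fold lower number (1.11 log units; beyond the scatter) from compound 1 to compound 4, 14-fold (1.13 log units) apart, beyond the scatter of two such steps. Among these compounds, this shows that a step read on one matched pair was a poor guide to the step on the other, but with only two pairs, which also differ in where the change sits, it does not show what sets the difference between them and gives no rule for any further core.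

Left open is whether the large step belongs to chloro itself or to the loss of trifluoromethyl from that place on the ring, which a bromo, a methyl or a nitrile at the same place on the core of compound 1 would help to separate. Among the compounds shown here, also open is whether the two steps stay this far apart with a longer chain or a shorter chain in place of the one shared by these compounds.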